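A few compounds are considered here, and "the series" means these few. Any claim that something is new, unique, unknown or untested is made for them only; others in the source may bear on it.

Compound 1 `O=C(O)CNC(=O)COc1ccc([C@H]2CC[C@]3(CC2)OOC2(O3)C3CC4CC(C3)CC2C4)cc1`: 12.5 ug/mL
Compound 2 `O=C(O)CCCCOc1ccc([C@H]2CC[C@]3(CC2)OOC2(O3)C3CC4CC(C3)CC2C4)cc1`: < 1.6 ug/mL (a limit, not a number)

Both compounds were measured in a physicochemical assay for solubility, read by nephelometry, in phosphate buffer, measured as kinetic solubility, with a stated time of 30 min, at pH 6.5; on this read-out higher numbers stand for higher solubility and lower numbers for lower solubility. Compound 2 has only a limit there, and no number: the limit of < 1.6 ug/mL in this assay, at which 1 of the 2 values shown sits. The next structure, compound 3 `CS(=O)(=O)NC(=O)COc1ccc([C@H]2CC[C@]3(CC2)OOC2(O3)C3CC4CC(C3)CC2C4)cc1`, changes compound 2 on a saturated chain carbon bound to an oxygen on an aromatic ring: (methylsulfonyl)carbamoyl in place of 3-carboxypropyl on a saturated chain carbon bound to an oxygen on an aromatic ring. Among the compounds with values here, one measured step bears on this change, an at least 7.8-fold lower number from compound 1 to compound 2 (0.89 log units; beyond the scatter), in which 3-carboxypropyl took the place of (carboxymethyl)carbamoyl. That step lay beyond the scatter. Within the data shown here, compound 3 also gives up the 3-carboxypropyl for a carbamoyl group, though a different one, so a higher number of similar size is expected in this assay, with compound 1 at 12.5 ug/mL as the only guide. The estimated step is an at least 7.5-fold higher number from compound 2 to compound 3 (0.87 log units; beyond the scatter). For compound 3 the expected value is 12 ug/mL, with an estimated range of 3 ug/mL to 50 ug/mL.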

Compound 3, solubility: < 1.6 ug/mL
Compound 3: a limit, no number (the forecaster's own chance of this, stated with the estimate: 15%); middle value at least 7.5-fold (0.87 log units) from the limit.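

Compound 3 gives < 1.6 ug/mL in this assay, which is a limit and not a number. Methylsulfonyl in place of carboxymethyl on an amide-type nitrogen brings an at least 7.8-fold lower number from compound 1 to compound 3 (0.89 log units; beyond the scatter), so a carbamoyl link at this place does not by itself keep a readable number: the group on that nitrogen matters as well. The step between compound 2 and compound 3 cannot be read, and the limit now holds most of the values shown: the limit of < 1.6 ug/mL in this assay, at which 2 of the 3 values shown sit.

As far as these compounds go, whether an aminoethyl or a hydroxyethyl group on the amide-type nitrogen would give a readable number in this assay stays open. From the compounds shown here alone, the true values of compound 2 and compound 3 also stay open, and so does any order between them.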